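The source may report more compounds than this note shows. Statements on the series, on what has been measured and on what is new or still open speak of the compounds shown alone.

Compound 1 `Cc1cc(N2CC[C@@H](C)[C@@H](N(C)c3ncnc4[nH]ccc34)C2)n2nc(SCCc3ccccc3)nc2n1`: 28000 nM
Compound 2 `Cc1cc(N2CC[C@@H](C)[C@@H](N(C)c3ncnc4[nH]ccc34)C2)n2nc(SCc3ccc(F)c(Cl)c3)nc2n1`: 98900 nM

For the measured compounds named here, in a functional assay on BGC-823 cells (Homo sapiens) for inhibition, read by MTT assay, with a stated time of 72 h (on this read-out lower numbers stand for stronger inhibition and higher numbers for weaker inhibition), compound 2 gives 98900 nM, the higher of the two numbers so far, and compound 1 gives 28000 nM. Compound 3 `Cc1cc(N2CC[C@@H](C)[C@@H](N(C)c3ncnc4[nH]ccc34)C2)n2nc(SCc3ccc(Br)cc3)nc2n1` keeps the shared core and differs from compound 2 at one place: 4-bromophenyl in place of 3-chloro-4-fluorophenyl on a saturated chain carbon bound to a sulfur. The change puts 4-bromophenyl in place of 3-chloro-4-fluorophenyl on a saturated chain carbon bound to a sulfur. Going by the values given here, only one measured step touches this place, a 3.5-fold higher number from compound 1 to compound 2 (0.55 log units; beyond the scatter), and it is modest. It is a different change, so it offers only a rough guide. A similarly modest move toward a lower number is expected, a 2.0-fold lower number from compound 2 to compound 3 (0.30 log units; within the scatter). For compound 3 the estimated value is 50000 nM, with an expected range of 15000 nM to 120000 nM.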

Compound 3, half-maximal inhibitory concentration: 28000 nM
Beside the measured number, compound 3's estimate is 1.8-fold (0.25 log units) above it; measured number inside the range.
By their numbers in this assay, from the lowest: compounds 1 and 3 (each within the scatter of the next); then compound 2.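

In this assay the 4-bromophenyl group gives a 3.5-fold lower number from compound 2 to compound 3 (0.55 log units; beyond the scatter) with the aromatic ring itself kept, so the ring's substituents alone can shift the number at this place. Set against the benzyl group, it gives no change at the digits printed from compound 1 to compound 3 (within the scatter) and so cannot be told apart from it here. Nothing available explains either step. The compounds shown leave open whether an amine or a carboxylic acid on this ring, or a longer chain on the sulfur, would shift the number further.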